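Furan to methoxyphenyl at the para position of the core aryl

This account rests on a few compounds, and the source may have more. Where it says the series, first, only, none or still open, it means among the compounds named here.

For the measured compounds named here, compound 1 `Cc1ccccc1-n1nc(C)c2c1NC(=O)[C@H](C)S[C@@H]2c1ccc(-c2ccoc2)cc1` sits in the middle of the three values measured so far. In an assay on isolated protein for agonist activity at Bile acid receptor (Homo sapiens), read by AlphaScreen, with a stated time of 30 min (a lower number here means a smaller maximal response, a higher number a larger maximal response), compound 1 gives 40%. Compound 2 `COc1cc([C@H]2S[C@@H](C)C(=O)Nc3c2c(C)nn3-c2ccccc2C)ccc1Oc1ccccc1` gives 130%, the largest response of the set and well beyond the scatter from compound 1. Compound 3 `Cc1ccc(-n2nc(C)c3c2NC(=O)[C@H](C)S[C@@H]3c2ccc(Oc3ccccc3)cc2)cc1` gives 11%, lower than compound 1 by a margin that also exceeds the scatter. No pair among these three differs in a single place, so no single-point step is available; the three values only show that the substituent carried by the aryl group on the shared core moves the maximal response across a wide span.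

Compound 4 `COc1cccc(-c2ccc([C@H]3S[C@@H](C)C(=O)Nc4c3c(C)nn4-c3ccccc3C)cc2)c1` is the next compound of the series. It differs from compound 1 in one place: 3-methoxyphenyl in place of furan-3-yl on an aromatic carbon. Going by the values given here, the 3-methoxyphenyl group that enters is larger than the furan-3-yl group that leaves, and the one measured compound with an oxygen-bearing aromatic extension at the same place, compound 2, reached 130%. A step upward from compound 1, of a size beyond the scatter, is therefore expected. The estimated step of a number 25 percentage points higher from compound 1 to compound 4 (beyond the scatter) reflects that expectation. For compound 4 the expected value is 65%, with a range from 25% to 120%.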

Compound 4, largest response reached (reported as efficacy), in percent of the reference or control that the assay uses: 41%
Compound 4: middle estimate off by 24 percentage points, on the high side; the range from low to high includes it.
By their numbers in this assay, from the lowest: compound 3; then compounds 1 and 4 (each within the scatter of the next); then compound 2.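

For the compounds shown here, compound 1 and compound 4 form the first pair that differs in one place. In this assay, replacing furan-3-yl with 3-methoxyphenyl on an aromatic carbon, para to a large group, gives a number 1 percentage points higher from compound 1 to compound 4 (within the scatter) and so leaves the maximal response unresolved from that of compound 1 within the usual scatter. At this place, therefore, going from a five-membered aromatic ring with 1 hetero atom and 5 heavy atoms to a six-membered all-carbon aromatic ring with 8 heavy atoms, with the single hydrogen-bond acceptor and the absence of donors and net charge unchanged, has no readable effect on the maximal response. Nothing at hand explains why the response stays level across this exchange.

A single step on one core cannot show whether this place is tolerant in general or whether these two groups merely happen to match. A carboxylic acid or an amine on the entering phenyl ring, or a longer chain such as ethoxy in place of methoxy, would test whether the response at this place can be moved at all.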